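The source may hold more compounds than are shown below. What is called first, only, known or untested is meant among the compounds shown, and "the series" means these compounds.

Measured compounds:
compound 1 `Cc1n[nH]c(C)c1Oc1c(O)cc(O)c2c(=O)cc(-c3ccc(N4CCCNCC4)cc3)oc12`, 17600 nM
compound 2 `COc1c(O)cc(O)c2c(=O)cc(-c3ccc(N4CCN(C=O)CC4)cc3)oc12`, 2200 nM
compound 3 `CCN1CCN(c2ccc(-c3cc(=O)c4c(O)cc(O)c(Oc5c(C)n[nH]c5C)c4o3)cc2)CC1`, 15500 nM

In an assay on cells for inhibition of ubiquitin carboxyl-terminal hydrolase 8 (Homo sapiens), read by fluorescence, with a stated time of 30 min (a higher number here means a weaker inhibitor, a lower number a stronger inhibitor), compound 2 gives the lowest number of the three, with compound 3 and compound 1 both well beyond the scatter above it. Compound 4 `COc1c(O)cc(O)c2c(=O)cc(-c3ccc(N4CCN(C)CC4)cc3)oc12` differs from compound 2 by methyl in place of formyl on an amine nitrogen in a ring. Among the compounds with values here, the only measured step, a 1.1-fold lower number from compound 1 to compound 3 (0.06 log units; within the scatter), concerns a different ring change and does not bear directly on this one. Compound 3 carries an alkyl group on the ring nitrogen and gives a higher number than compound 2, yet the two also differ elsewhere, so this is no clean guide. Compound 4 is therefore expected to give 4500 nM, within 1500 nM to 14000 nM, a step of a 2.0-fold higher number from compound 2 to compound 4 (0.31 log units; beyond the scatter) that is estimated to be modest.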

Compound 4, half-maximal inhibitory concentration: 16500 nM
Estimate against measurement, compound 4: 3.7-fold (0.56 log units) below; the whole stated range lies below it.
By their numbers in this assay, from the lowest: compound 2; then compounds 3, 4 and 1 (each within the scatter of the next).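

In this assay the group on the amine nitrogen in the ring clearly matters: putting methyl in place of formyl gives a 7.5-fold higher number from compound 2 to compound 4 (0.88 log units; beyond the scatter) with the rest of the molecule unchanged. The earlier compounds shown here could not show this, since no pair among them differed only at this nitrogen. Nothing measured here explains the size of this step. Going by these compounds, it remains open whether the carbonyl of the formyl group is what counts, and how an acetyl group or a plain hydrogen on this nitrogen would compare.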